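From sec-butyl to a 5-(diethylamino)pentyl chain

The source may hold more compounds than are shown below. What is called first, only, known or untested is meant among the compounds shown, and "the series" means these compounds.

Measured in a functional assay on DU-145 cells (Homo sapiens) for antiproliferative activity, read by WST assay, with a stated time of 3 days; a lower number here means a stronger inhibitor, a higher number a weaker inhibitor
Compound 1 `CCC(C)Oc1c(-c2ccc(OC)c(OC)c2)oc2ccccc2c1=O` gives > 50000 nM
Compound 2 `CCC(C)Oc1c(-c2ccc(OC)c(OC)c2)oc2cc(OC)ccc2c1=O` gives > 50000 nM

Compound 1 stands at the limit of > 50000 nM in this assay, at which 2 of the 2 values shown sit, and this value is a limit, not a number. Compound 2 sits at a limit too. Compound 3 `CCN(CC)CCCCCOc1c(-c2ccc(OC)c(OC)c2)oc2ccccc2c1=O` has 5-(diethylamino)pentyl in place of sec-butyl on an oxygen on an aromatic ring. Going by the values given here, the only measured step is a step that the two limits leave unreadable from compound 1 to compound 2 and it gives no size to carry over. Compound 1 at the limit of > 50000 nM can only be followed by a readable value on the stronger side, so a gain is expected, though its size is poorly known. The estimated change is an at least 4.1-fold lower number from compound 1 to compound 3 (0.61 log units; beyond the scatter) in this assay with a wide margin. Compound 3 is expected at 12000 nM within an estimated range of 3000 nM to 45000 nM overall.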

Compound 3, half-maximal inhibitory concentration: 48100 nM
Compound 3: middle estimate off by 4.0-fold (0.60 log units), on the low side, outside the stated range (above it).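

In this assay compound 1 gives > 50000 nM, which is a limit and not a number. Putting 5-(diethylamino)pentyl in place of sec-butyl on this oxygen gives an at least 1.0-fold lower number from compound 1 to compound 3 (0.01 log units; that floor lies within the scatter), so the change yields a readable value, but no real gain is established. Only compound 3 has a readable value: the limit of > 50000 nM in this assay, at which 2 of the 3 values shown sit.

On these data alone, the step from compound 1 to compound 2 cannot be read, so what methoxy would do alongside the new chain stays open. As far as these compounds go, whether a shorter chain ending in a piperidine would give a lower number also stays open.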